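Moving the methoxy group: compound 4 against compound 1

A few compounds are considered here, and "the series" means these few. Any claim that something is new, unique, unknown or untested is made for them only; others in the source may bear on it.

Compounds measured so far:
- compound 1, `Cc1ccc(NC(=O)Nc2nnc(Sc3ncnc4scc(-c5ccncc5)c34)s2)cc1Cl`: 4700 nM
- compound 2, `COc1ccc(NC(=O)Nc2nnc(Sc3ncnc4scc(-c5ccncc5)c34)s2)cc1`: 9900 nM
- compound 3, `O=C(Nc1ccc(F)cc1)Nc1nnc(Sc2ncnc3scc(-c4ccncc4)c23)s1`: 970 nM

In a functional assay on PC-3 cells (Homo sapiens) for antiproliferative activity, read by MTT assay, with a stated time of 48 h (a lower number here means a stronger inhibitor, a higher number a weaker inhibitor), compound 1 gives 4700 nM, the second highest of the three numbers. Its nearest neighbour is compound 2, which gives 9900 nM, and the furthest is compound 3, which gives 970 nM, the lowest number of the set.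

Compound 4, `COc1cccc(NC(=O)Nc2nnc(Sc3ncnc4scc(-c5ccncc5)c34)s2)c1`, has not yet been measured. It differs from compound 1 in one place: 3-methoxyphenyl in place of 3-chloro-4-methylphenyl on an amide-type nitrogen. The closest measured step is a 2.1-fold higher number from compound 1 to compound 2 (0.32 log units; beyond the scatter), where a methoxyphenyl group also replaced the 3-chloro-4-methylphenyl group, though with the methoxy group at a different position of the ring. The step of a 4.8-fold lower number from compound 1 to compound 3 (0.69 log units; beyond the scatter) shows that a small change in this part of the molecule can lower the number appreciably, and a 10-fold lower number from compound 2 to compound 3 (1.01 log units; beyond the scatter) shows that a methoxy group gave the highest number among the three. Among the compounds with values here, no measured pair separates a 3-methoxyphenyl group from a 4-methoxyphenyl group.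

On this basis compound 4 is expected to land close to compound 1, with a modest rise in the number as the more likely direction, a 1.4-fold higher number from compound 1 to compound 4 (0.14 log units; within the scatter). The estimate for compound 4 in this assay is 6500 nM, with a range from 2500 nM to 16000 nM.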

Compound 4, half-maximal inhibitory concentration: 6800 nM
Compound 4: the middle estimate sits 1.0-fold (0.02 log units) below what was measured, and the stated range covers the measured number.
By their numbers in this assay, from the lowest: compound 3; then compounds 1, 4 and 2 (each within the scatter of the next, the first and the last beyond it).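

In this assay, the pair that separates a 3-methoxyphenyl group from a 4-methoxyphenyl group reads a 1.5-fold lower number from compound 2 to compound 4 (0.16 log units; within the scatter), so for these two compounds the place of the methoxy group on the ring makes no difference beyond the scatter. The exchange of 3-chloro-4-methylphenyl for 3-methoxyphenyl, which keeps the count of heavy atoms and adds one hydrogen-bond acceptor, reads a 1.4-fold higher number from compound 1 to compound 4 (0.16 log units; within the scatter), and so it also leaves the number within the scatter, whereas the 4-methoxyphenyl group of compound 2 lies just beyond it in a 2.1-fold higher number from compound 1 to compound 2 (0.32 log units; beyond the scatter). The third step, a 7.0-fold higher number from compound 3 to compound 4 (0.85 log units; beyond the scatter), shows that the 4-fluorophenyl group of compound 3 stands apart from the second methoxyphenyl group as well, and compound 3 now lies beyond the scatter of all three other compounds. Nothing shown here accounts for these steps.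

The compounds shown leave open whether the low number of compound 3 is particular to fluoro or would also appear with a plain phenyl or a 4-chlorophenyl group. They also leave open how a phenyl ring carrying an amine or a carboxylic acid would read in this assay at this amide-type nitrogen.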